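The compounds below may be only part of what the source reports. "The series", "measured", "known", "first", "only" and "open" are said of these compounds alone.

Going by the values given here, in a functional assay on KB cells (Homo sapiens) for inhibition, with a stated time of 72 h (on this read-out lower numbers stand for stronger inhibition and higher numbers for weaker inhibition), compound 1 `COc1cc(C(=O)c2cccc3[nH]ccc23)cc(OC)c1OC` gives 50.7 nM, the lowest of the three numbers measured so far. Its isomer, compound 2 `COc1cc(C(=O)c2ccc3[nH]ccc3c2)cc(OC)c1OC`, gives 104 nM, a number higher than that of compound 1 by a margin just beyond the usual scatter. A second isomer, compound 3 `COc1cc(C(=O)c2ccc3cc[nH]c3c2)cc(OC)c1OC`, gives 510 nM, which lies well beyond the scatter from compound 1. The next compound, compound 4 `COc1cc(C(=O)c2cccc3c2ccn3C)cc(OC)c1OC`, is not yet measured. It departs from compound 1 by one small change, methyl in place of hydrogen on an aromatic nitrogen. Among the compounds with values here, none of the three measured compounds carries this methyl, so the data offer no direct precedent for the change, and the isomers show only that the read-out responds to the arrangement of the core. Within the data shown here, with so small a change and no precedent, little movement is expected, most likely none beyond the scatter. The estimated step is a 1.2-fold higher number from compound 1 to compound 4 (0.07 log units; within the scatter). For compound 4, the expected value is 60 nM, with an estimated range from 15 nM to 250 nM.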

Compound 4, half-maximal inhibitory concentration: 22.1 nM
For compound 4 the middle estimate is 2.7-fold (0.43 log units) above the measured one, and the stated range covers the measured number.
By their numbers in this assay, from the lowest: compound 4; then compound 1; then compound 2; then compound 3.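

In this assay, the hydrogen on the aromatic nitrogen of the five-membered ring proves dispensable: methyl in its place gives a 2.3-fold lower number from compound 1 to compound 4 (0.36 log units; beyond the scatter), a modest step that lies beyond the usual scatter. The earlier isomers said nothing about this position, and it now appears that one added carbon here lowers the number rather than raising it, leaving compound 4 with the lowest number of the four compounds. Nothing among the data shown accounts for this step.

The compounds shown leave open whether a longer chain such as ethyl or propyl, or a chain ending in an amine or a carboxylic acid, would be accepted on this nitrogen. They also leave open whether the same methyl would lower the numbers of compound 2 and compound 3, whose cores are arranged differently.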